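A few compounds are considered here, and "the series" means these few. Any claim that something is new, unique, unknown or untested is made for them only; others in the source may bear on it.

In a functional assay on HeLa cells (Homo sapiens) for cytotoxicity, read by CCK-8 assay, with a stated time of 16 h (on this read-out higher numbers stand for weaker inhibition and lower numbers for stronger inhibition), compound 1 `COc1ccc(C2=[N+]3C(=Nc4c(-c5ccccc5)c5c(n4[B-]3(F)F)-c3ccc(OCC(=O)N[C@@H](CCC(=O)O)C(=O)O)cc3CC5)C(c3ccccc3)=C2I)cc1` gives > 250000 nM, which is a limit and not a number. Compound 2 `COc1ccc2c(c1)CCc1c(-c3ccccc3)c3n(c1-2)[B-](F)(F)[N+]1=C(c2ccc(OCC(=O)O)cc2)C(I)=C(c2ccccc2)C1=N3` gives > 50000 nM, also a limit, so compound 2 has no exact value on this read-out. Compound 3 `COc1ccc2c(c1)CCc1c(-c3ccccc3)c3n(c1-2)[B-](F)(F)[N+]1=C(c2ccc(OCC(=O)N[C@@H](CC(=O)O)C(=O)O)cc2)C(I)=C(c2ccccc2)C1=N3` carries (1,2-dicarboxyethyl)amino in place of hydroxy on a carbonyl carbon. Going by the values given here, no measured pair shows what such a change does. The expectation therefore leans on compound 1, whose limit of > 250000 nM gives no number either. A modest expected shift toward weaker inhibition is estimated as a step that the limit leaves unreadable from compound 2 to compound 3. For compound 3, the estimated value is 200000 nM, with an expected range of 50000 nM to 500000 nM.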

Compound 3, half-maximal inhibitory concentration: > 250000 nM
Compound 3: a limit, no number; the forecaster's own chance of this, stated with the estimate: 90%; at least 1.2-fold (0.09 log units) between middle value and limit.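

Going by these compounds alone, compound 2 and compound 3 both give only limits, not numbers, so no step between them can be read. The compounds shown leave open what exact value any of them has, and what swapping hydroxy for (1,2-dicarboxyethyl)amino does.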